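The source may hold more compounds than are shown below. What is called first, only, known or untested is meant among the compounds shown, and "the series" means these compounds.

Measured so far in an assay on HEK293 cells for displacement of a labelled ligand from Sigma non-opioid intracellular receptor 1 (Homo sapiens), read by scintillation counting, with a stated time of 120 min; on this read-out higher numbers stand for weaker inhibition and lower numbers for stronger inhibition:
compound 1, `CNC1CCN(c2ncnc3c2cnn3CCN2CCCCC2)C1`: 25800 nM
compound 2, `COc1ccc(-c2ncnc3c2cnn3CCN2CCCCC2)cc1`: 531 nM

Among the compounds with values here, of these two numbers, compound 2 gives the lower one; the only measured step, a 49-fold lower number from compound 1 to compound 2 (1.69 log units; beyond the scatter), separates them and is a large one. Compound 3, `Clc1ccc(-c2ncnc3c2cnn3CCN2CCCCC2)cc1`, is not yet measured. It differs from compound 2 in a single place: chloro in place of methoxy on an aromatic carbon. Within the data shown here, no measured step bears on this change, since the one step seen so far put 4-methoxyphenyl in place of 3-(methylamino)pyrrolidin-1-yl and does not speak to trading one substituent on the phenyl for another. With no guide from the data, compound 3 is expected to sit close to compound 2, with an expected step of a 1.3-fold lower number from compound 2 to compound 3 (0.12 log units; within the scatter) that may well fall within the scatter. On that basis compound 3 is estimated at 400 nM in this assay, with a range from 100 nM to 2000 nM.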

Compound 3, inhibition constant: 43 nM
Compound 3: middle estimate off by 9.3-fold (0.97 log units), on the high side; the measured number lies below the stated range.
By their numbers in this assay, from the lowest: compound 3; then compound 2; then compound 1.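

Up to now, the only measured step had replaced 3-(methylamino)pyrrolidin-1-yl with 4-methoxyphenyl, leaving it unknown whether the substituent on that aromatic ring mattered in this assay. This position, para to a large group, proves sensitive: chloro in place of methoxy gives a 12-fold lower number from compound 2 to compound 3 (1.09 log units; beyond the scatter) in exchange for a single heavy atom and the loss of one hydrogen-bond acceptor. The aryl exchange itself now reaches a 600-fold lower number from compound 1 to compound 3 (2.78 log units; beyond the scatter) with 4-chlorophenyl as the entering group, so its size depends on what the ring carries, and nothing here explains the chloro result.

The compounds shown leave open how fluoro, bromo, methyl or trifluoromethyl would read at this position. They also leave open whether chloro would give a similar number elsewhere on the ring.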